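The source may report more compounds than this note shows. Statements on the series, on what has been measured and on what is new or still open speak of the compounds shown alone.

Measured compounds: compound 1 `N#Cc1c(-c2ccco2)nc2c(c(-c3ccccc3)nn2-c2ccccc2)c1-c1ccc(O)cc1` gives 12800 nM in a functional assay on ML-2 cells (Homo sapiens) for antiproliferative activity, read by resazurin assay, with a stated time of 72 h; on this read-out lower numbers stand for stronger inhibition and higher numbers for weaker inhibition; compound 2 `COc1ccc(-c2nc3c(c(-c4ccccc4)nn3-c3ccccc3)c(-c3ccc(O)cc3)c2C#N)cc1` gives 400 nM; compound 3 `N#Cc1c(-c2ccc(F)cc2)nc2c(c(-c3ccccc3)nn2-c2ccccc2)c1-c1ccc(O)cc1` gives 6700 nM.

Compound 3 stands second highest of the three numbers; compound 1 is its nearest neighbour, with a 1.9-fold lower number from compound 1 to compound 3 (0.28 log units; within the scatter), and compound 2 its furthest, with a 17-fold higher number from compound 2 to compound 3 (1.22 log units; beyond the scatter). Compound 4 `Cc1ccc(-c2nc3c(c(-c4ccccc4)nn3-c3ccccc3)c(-c3ccc(O)cc3)c2C#N)cc1` differs from compound 3 by methyl in place of fluoro on an aromatic carbon. For the measured compounds named here, the one step at this same position is the large one, a 17-fold higher number from compound 2 to compound 3 (1.22 log units; beyond the scatter), where methoxy replaced fluoro; a 32-fold lower number from compound 1 to compound 2 (1.51 log units; beyond the scatter) shows the same group from the furan-2-yl side. Going by the values given here, no measured step involves methyl, so the size is uncertain. A moderately lower number, a 1.9-fold lower number from compound 3 to compound 4 (0.28 log units; within the scatter), is expected, and compound 4 is estimated at 3500 nM with a range of 900 nM to 13000 nM.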

Compound 4, half-maximal inhibitory concentration: 1400 nM
Compound 4: the middle estimate sits 2.5-fold (0.40 log units) above what was measured; low and high end bracket the measured number.
By their numbers in this assay, from the lowest: compound 2; then compound 4; then compounds 3 and 1 (each within the scatter of the next).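

In this assay, methyl in place of fluoro gives a gain beyond the scatter, a 4.8-fold lower number from compound 3 to compound 4 (0.68 log units; beyond the scatter), even though only one heavy atom is exchanged for another. Methoxy still gives the lowest number at this position, a 3.5-fold higher number from compound 2 to compound 4 (0.54 log units; beyond the scatter), so methyl falls between methoxy and fluoro. The 4-methylphenyl group also clearly improves on furan-2-yl, a 9.1-fold lower number from compound 1 to compound 4 (0.96 log units; beyond the scatter).

No measurement shown explains this order. Going by these compounds, whether an ethyl group, an amine or a hydroxyl at this position would lower the number further remains open.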